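The source may hold more compounds than are shown below. What is called first, only, known or untested is meant among the compounds shown, and "the series" means these compounds.

Compound 1 `COc1nc(-c2ccc(Br)cc2)ccc1[C@@H](c1ccccc1)[C@@](O)(CCN(C)C)c1cccc2ccccc12` is tested in a toxicity assay on HeLa cells (Homo sapiens) for cytotoxicity; a lower number here means that less compound is tolerated, a higher number that more compound is tolerated. For compound 1 the result is only a limit, > 64 ug/mL, not a number; it sits at the limit of > 64 ug/mL in this assay, at which 1 of the 3 values shown sits. Compound 2 `COc1ncc(-c2ccccc2)cc1[C@@H](c1ccccc1)[C@@](O)(CCN(C)C)c1cc(F)ccc1F` has no reported result, "nd" (no result reported). Compound 3 `COc1ncc(-c2ccccc2)cc1[C@@H](c1ccccc1)[C@@](O)(CCN(C)C)c1cc(F)cc(F)c1` gives 28.8 ug/mL in this assay. For the measured compounds named here, no single-point step connects compound 1 with compound 2 or compound 3, so compound 1 stands only at its limit. Compound 4 `COc1nc(-c2ccc(Cl)c(F)c2)ccc1[C@@H](c1ccccc1)[C@@](O)(CCN(C)C)c1cccc2ccccc12` differs from compound 1 by 4-chloro-3-fluorophenyl in place of 4-bromophenyl on an aromatic carbon. Going by the values given here, with no measured step to draw on, the expected step in this assay is none beyond the scatter, and compound 4 is estimated at 70 ug/mL, between 35 ug/mL and 140 ug/mL, which means an expected step that the limit leaves unreadable from compound 1 to compound 4.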

Compound 4, half-maximal cytotoxic concentration: > 64 ug/mL
Compound 4: a limit, no number (the forecaster's own chance of this, stated with the estimate: 65%); the middle value does not contradict the limit.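

Compound 1 and compound 4 each give only a limit, not a number, so no step can be read between them: the limit of > 64 ug/mL in this assay, at which 2 of the 4 values shown sit.

The compounds shown leave open whether 4-chloro-3-fluorophenyl in place of 4-bromophenyl changes the result at all.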